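The source may hold more compounds than are shown below. What is called first, only, known or untested is meant among the compounds shown, and "the series" means these compounds.

In a functional assay on the whole organism with Mus musculus as the target, in the maximal electroshock model (a higher number here means that more compound is needed for the effect, a lower number that less compound is needed), compound 1 `O=C(Cc1ccccc1)NS(=O)(=O)C(F)(F)F` gives 6.2 mg/kg, compound 2 `O=C(Cc1ccc(Br)cc1)NS(=O)(=O)C(F)(F)F` gives 23 mg/kg, and compound 3 `O=C(Cc1cccc(Cl)c1)NS(=O)(=O)C(F)(F)F` gives 6.8 mg/kg. Compound 3 therefore sits level with compound 1, and compound 2 alone needs clearly more compound.

The change to follow leads to compound 4 `COc1cccc(CC(=O)NS(=O)(=O)C(F)(F)F)c1`, which carries methoxy in place of chloro on an aromatic carbon, meta to a large group (methoxy in place of chloro on an aromatic carbon).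

Among the compounds with values here, no measured compound carries methoxy, so the evidence is indirect. Chloro in place of hydrogen gave a 1.1-fold higher number from compound 1 to compound 3 (0.04 log units; within the scatter), and this is the closest guide. Bromo in place of hydrogen gave a 3.7-fold higher number from compound 1 to compound 2 (0.57 log units; beyond the scatter), which shows that a new group on the ring can shift the number by a modest amount.

In this assay, only a small move towards a higher number is therefore expected, with nothing clearly beyond the scatter. The expected change is a 1.3-fold higher number from compound 3 to compound 4 (0.12 log units; within the scatter). For compound 4 the estimate is 9 mg/kg, with an expected range from 4 mg/kg to 22 mg/kg.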

Compound 4, dose for half-maximal effect: 19 mg/kg
For compound 4 the middle estimate is 2.1-fold (0.32 log units) below the measured one, within the range that was stated.
By their numbers in this assay, from the lowest: compounds 1 and 3 (each within the scatter of the next); then compounds 4 and 2 (each within the scatter of the next).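

Chloro in place of hydrogen left the number within the scatter, but at this same place, meta to a large group, methoxy in place of hydrogen gives a 3.1-fold higher number from compound 1 to compound 4 (0.49 log units; beyond the scatter) and methoxy in place of chloro gives a 2.8-fold higher number from compound 3 to compound 4 (0.45 log units; beyond the scatter) in this assay on this ring. The position therefore does not accept every group equally, and the result for chloro cannot be carried over to methoxy. No measurement shown explains this shift, so it remains unknown which difference between the two groups matters.

The compounds shown leave open how a hydroxyl, an amine or a longer ether such as ethoxy would fare at this place. They also leave open how methoxy or chloro would behave at the ring position that holds bromo in compound 2.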